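The source may report more compounds than this note shows. Statements on the series, on what has been measured and on what is new or still open speak of the compounds shown alone.

Measured compounds:
compound 1, `C=C(Br)C(=O)Nc1ccc(/C=C/C(=O)c2ccccc2)cc1`: 4000 nM
compound 2, `C=C(Br)C(=O)Nc1ccc(/C=C/C(=O)c2ccc(OC)cc2)cc1`: 1400 nM
compound 3, `C=C(Br)C(=O)Nc1ccc(C(=O)/C=C/c2ccccc2)cc1`: 1500 nM

All three were tested in an ADME assay on CCRF-CEM cells (Homo sapiens) for antiproliferative activity, with a stated time of 48 h; on this read-out higher numbers stand for weaker inhibition and lower numbers for stronger inhibition. In this assay compound 1 gives 4000 nM, compound 2 gives 1400 nM and compound 3 gives 1500 nM.

Compound 2 differs from compound 1 in a single place: methoxy in place of hydrogen on an aromatic carbon. That change produced a 2.9-fold lower number from compound 1 to compound 2 (0.46 log units; beyond the scatter), a step that goes beyond the usual scatter of repeated measurements.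

Compound 3 is built from the same atoms as compound 1, joined in a different way; the difference between the two cores is not broken down here. The numbers of compound 3 and compound 2 lie within the scatter of each other, so they cannot be told apart on this read-out.

Compound 4, `C=C(Br)C(=O)Nc1ccc(C(=O)/C=C/c2ccc(OC)cc2)cc1`, has not yet been measured. It differs from compound 3 in one place: methoxy in place of hydrogen on an aromatic carbon. This is the same change that turns compound 1 into compound 2, set on the core of compound 3, and the surroundings of the place match word for word. Within the data shown here, the expectation for compound 4 rests on the step of a 2.9-fold lower number from compound 1 to compound 2 (0.46 log units; beyond the scatter), which is the only measured example of this change. As the starting point it takes the value of compound 3, which gives 1500 nM. The step from compound 3 to compound 4 is expected to be a 2.5-fold lower number from compound 3 to compound 4 (0.40 log units; beyond the scatter). Compound 4 is therefore estimated to give about 600 nM in this assay. The likely range for compound 4 is estimated to run from 250 nM to 1500 nM.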

Compound 4, half-maximal inhibitory concentration: 1100 nM
Compound 4: the middle estimate sits 1.8-fold (0.26 log units) below what was measured; low and high end bracket the measured number.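

Methoxy in place of hydrogen on an aromatic carbon gives a 1.4-fold lower number from compound 3 to compound 4 (0.13 log units; within the scatter) in this assay, a step that stays within the scatter, while the same change on the other core gave a 2.9-fold lower number from compound 1 to compound 2 (0.46 log units; beyond the scatter), a step that goes beyond it. Among these compounds, although only one of these two steps stands clear of the scatter, the gap between them is no larger than two such steps can show by chance: the same change on two cores in this assay, a 2.9-fold lower number (0.46 log units; beyond the scatter) from compound 1 to compound 2 and a 1.4-fold lower number (0.13 log units; within the scatter) from compound 3 to compound 4, 2.1-fold (0.32 log units) apart, within the scatter of two such steps. This gives no firm ground for saying that the change behaves differently on the two cores, but it does not prove that it behaves the same, and two examples are too few to make a rule for carrying it across this series.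

As far as these compounds go, the only replacement for hydrogen at this place on the ring, para to a large group, is methoxy, so it stays open whether a chlorine atom, an amine or a carboxylic acid there would give steps that match on both cores. From the compounds shown here alone, it also stays open whether a larger step on the core of compound 3 would appear with a longer chain on the oxygen, such as ethoxy or butoxy.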